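This account rests on a few compounds, and the source may have more. Where it says the series, first, only, none or still open, it means among the compounds named here.

Measured in a functional assay on HL-60 cells (Homo sapiens) for inhibition, read by MTT assay, with a stated time of 72 h; a lower number here means a stronger inhibitor, a higher number a weaker inhibitor:

- Compound 1 `COc1cccc(N2CCN(C(=O)c3oc(C(F)(F)F)nc3-c3cccc(F)c3)CC2)c1` gives "not active" (no number reported)
- Compound 2 `O=C(c1oc(C(F)(F)F)nc1-c1cccc(F)c1)N1CCN(c2cccc(Cl)c2)CC1` gives "not active" (no number reported)
- Compound 3 `CCc1nc(-c2cccc(F)c2)c(C(=O)N2CCN(c3cccc(Cl)c3)CC2)o1` gives 317 nM

Compound 2 has no single number to stand on. In this assay compound 2 is reported as "not active" (no number reported), and compound 1 is the one other entry of this kind, at "not active" (no number reported). Only compound 3 carries a number, at 317 nM.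

Compound 4 `O=C(c1oc(C(F)(F)F)nc1-c1ccc(F)cc1)N1CCN(c2cccc(Cl)c2)CC1` comes from compound 2 by one change: 4-fluorophenyl in place of 3-fluorophenyl on an aromatic carbon. This places 4-fluorophenyl in place of 3-fluorophenyl on an aromatic carbon, next to the ring nitrogen. The two compounds have the same atoms, joined differently.

Among the compounds with values here, no measured pair here shows what such a change does, and the size of a step from a compound without a number cannot be stated. The expectation therefore rests on compound 2 itself, at "not active" (no number reported): no step beyond the scatter is expected, and compound 4 may well be reported without a number in this assay too. Any number that does appear is expected to be higher than that of compound 3, at 317 nM. If a number is reported, the estimate for compound 4 is 4000 nM, with an expected range of 700 nM to 25000 nM.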

Compound 4, half-maximal inhibitory concentration: "not active" (no number reported)
For compound 4 the study gives words and no number; no gap can be computed for the estimate.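

In this assay compound 2 gives "not active" (no number reported) and compound 4 gives "not active" (no number reported) as well, so no step can be read between them. Nothing shown here bears on this result. Going by these compounds, whether 4-fluorophenyl in place of 3-fluorophenyl shifts activity at all stays open, as does the size of any such shift.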